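Cytotoxicity notes on an aryl-swap series, compound 4

The compounds below may be only part of what the source reports. "The series", "measured", "known", "first", "only" and "open" are said of these compounds alone.

Compound 1 `CCOC(=O)C1=C(C)N/C(=C/c2cc(C)n(-c3ccc(F)cc3F)c2C)C1=O` is the reference point of this set. In an ADME assay on L6 cells (Rattus norvegicus) for cytotoxicity, read by resazurin assay, with a stated time of 72 h (on this read-out lower numbers stand for an effect already at smaller amounts and higher numbers for an effect only at larger amounts of compound), compound 1 gives 14000 nM, the lowest number among the three measured compounds. Compound 2 `CCOC(=O)C1=C(C)N/C(=C/c2cc(C)n(-c3ccc(Br)cc3)c2C)C1=O` gives 100000 nM in this assay, and compound 3 `CCOC(=O)C1=C(C)N/C(=C/c2cc(C)n(-c3ccc(S(=O)(=O)C(F)(F)F)cc3)c2C)C1=O` gives 120000 nM. Among the measured compounds shown here, the step of a 7.1-fold higher number from compound 1 to compound 2 (0.85 log units; beyond the scatter) is the only measured exchange of the group on the aromatic nitrogen; the step of a 1.2-fold higher number from compound 2 to compound 3 (0.08 log units; within the scatter) exchanges one group for another on an aromatic carbon and stays within the scatter.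

Compound 4 `CCOC(=O)C1=C(C)N/C(=C/c2cc(C)n(-c3ccc(SC)cc3)c2C)C1=O` has not yet been measured. It differs from compound 1 in one place: 4-(methylsulfanyl)phenyl in place of 2,4-difluorophenyl on an aromatic nitrogen. The measured step that bears on this is a 7.1-fold higher number from compound 1 to compound 2 (0.85 log units; beyond the scatter), in which the same 2,4-difluorophenyl leaves and a phenyl carrying a single bromo group enters, and the number moved upward beyond the scatter. For the measured compounds named here, the step of a 1.2-fold higher number from compound 2 to compound 3 (0.08 log units; within the scatter) shows that exchanging one such single group for another left the number within the scatter, though only two such groups have been compared, so no broader rule is claimed. An upward step of comparable size is therefore expected for compound 4, a 4.3-fold higher number from compound 1 to compound 4 (0.63 log units; beyond the scatter). Compound 4 is estimated to give 60000 nM in this assay, with a range from 20000 nM to 150000 nM.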

Compound 4, half-maximal effective concentration in the L6 assay: 54000 nM
The estimate for compound 4 lay 1.1-fold (0.05 log units) above the measured number, and the stated range covers the measured number.
By their numbers in the L6 assay, from the lowest: compound 1; then compounds 4, 2 and 3 (each within the scatter of the next, the first and the last beyond it).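

In the L6 assay, a second phenyl carrying a single group on this aromatic nitrogen also moves the number upward from 2,4-difluorophenyl, with a 3.9-fold higher number from compound 1 to compound 4 (0.59 log units; beyond the scatter), so the low number of compound 1 no longer rests on the bromo compound alone. Among the compounds shown here, the single group is not wholly without consequence either: in the L6 assay, methylsulfanyl and bromo stay together, with a 1.9-fold lower number from compound 2 to compound 4 (0.27 log units; within the scatter), while methylsulfanyl and (trifluoromethyl)sulfonyl separate, with a 2.2-fold lower number from compound 3 to compound 4 (0.35 log units; beyond the scatter), a difference that compounds 2 and 3 alone did not show. The exchange on the aromatic nitrogen also comes with a fall in a physicochemical assay for solubility, read by nephelometry, in phosphate buffer, measured as kinetic solubility, at pH 6.5; a lower number here means a less soluble compound, a higher number a more soluble compound (compound 1 gives 6.3 ug/mL and compound 4 gives 1.6 ug/mL): the measured solubility of compound 1, 6.3 ug/mL, and of compound 4, 1.6 ug/mL, a 3.9-fold lower number (0.60 log units; beyond the scatter)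

On these data alone, it stays open whether a phenyl carrying a single fluoro group would stand with compound 1 or with compounds 2, 3 and 4 in the L6 assay, which would tell whether the 2,4-difluorophenyl pattern as a whole goes with the lower number. As far as these compounds go, it also stays open whether a phenyl carrying an amine or a carboxylic acid on this aromatic nitrogen would keep the higher number in the L6 assay while giving a different number in the physicochemical assay.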